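Swapping the aryl ring on the cyclopropane for a thiazole

This account rests on a few compounds, and the source may have more. Where it says the series, first, only, none or still open, it means among the compounds named here.

Three measured compounds share one core and differ only in the ring attached to the three-membered ring. Compound 1, `CC[C@H](C)[C@H](N)CN(C(=O)[C@@H]1C[C@H]1c1cccc(Cl)c1)c1ccc(-c2ccccc2)cc1`, gives 2200 nM in a functional assay for agonist activity at G protein-coupled receptor 88 (Homo sapiens), read by HTRF and cAMP accumulation; on this read-out higher numbers stand for an effect only at larger amounts of compound and lower numbers for an effect already at smaller amounts. Compound 2, `CC[C@H](C)[C@H](N)CN(C(=O)[C@@H]1C[C@H]1c1cccc(C)c1)c1ccc(-c2ccccc2)cc1`, gives 1200 nM, and compound 3, `CC[C@H](C)[C@H](N)CN(C(=O)[C@@H]1C[C@H]1c1ccc(F)c(F)c1)c1ccc(-c2ccccc2)cc1`, gives 720 nM. The move a 1.8-fold lower number from compound 1 to compound 2 (0.26 log units; within the scatter) stays within the scatter, while a 3.1-fold lower number from compound 1 to compound 3 (0.49 log units; beyond the scatter) is a modest gain and a 1.7-fold lower number from compound 2 to compound 3 (0.22 log units; within the scatter) again lies within the scatter. Compound 3 therefore shows the lowest number of the three, separated clearly only from compound 1.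

Compound 4, `CC[C@H](C)[C@H](N)CN(C(=O)[C@@H]1C[C@H]1c1nccs1)c1ccc(-c2ccccc2)cc1`, carries the change (1,3-thiazol-2-yl in place of 3,4-difluorophenyl on a saturated ring carbon). Going by the values given here, the steps that bear on it, from compound 1 and compound 2 to compound 3, all swapped one substituted benzene ring for another and moved the number only modestly. None of them replaced the benzene ring by a five-membered heteroaromatic ring, so the bearing is weak. A shift toward higher numbers is expected as a 2.5-fold higher number from compound 3 to compound 4 (0.40 log units; beyond the scatter), and compound 4 is estimated at 1800 nM, within a range from 500 nM to 7000 nM.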

Compound 4, half-maximal effective concentration: 210 nM
The estimate for compound 4 lay 8.6-fold (0.93 log units) above the measured number, outside the stated range (below it).
By their numbers in this assay, from the lowest: compound 4; then compounds 3, 2 and 1 (each within the scatter of the next, the first and the last beyond it).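

In this assay, this carbon of the cyclopropane does not need a benzene ring: 1,3-thiazol-2-yl in place of 3,4-difluorophenyl gives a 3.4-fold lower number from compound 3 to compound 4 (0.54 log units; beyond the scatter) and leaves compound 4 with the lowest number of the four. The same swap gives a 5.7-fold lower number from compound 2 to compound 4 (0.76 log units; beyond the scatter) against 3-methylphenyl and a 10-fold lower number from compound 1 to compound 4 (1.02 log units; beyond the scatter) against 3-chlorophenyl, so changing the kind of ring here moves the number further than any change among the substituted benzene rings. Nothing available explains this gain.

The compounds shown leave open whether the gain belongs to the ring nitrogen, the ring sulfur or the five-membered ring itself. A thiophene, an oxazole or a pyridine at this carbon would help separate these, and a methyl group on the thiazole would test whether the ring accepts a substituent.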